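The source may report more compounds than this note shows. Statements on the series, on what has been measured and on what is new or still open speak of the compounds shown alone.

Compound 1 `CCc1ccc(C(=O)N[C@@H]2[C@@H](O)[C@H](n3cnc4c(NC5CCCC5)ncnc43)O[C@@H]2C)cc1` gives 240 nM in an assay on isolated protein for binding affinity to adenosine receptor A1 (Rattus norvegicus), in the absence of a further agent (a higher number here means a weaker inhibitor, a lower number a stronger inhibitor), and compound 2 `CC(C)c1ccc(C(=O)N[C@@H]2[C@@H](O)[C@H](n3cnc4c(NC5CCCC5)ncnc43)O[C@@H]2C)cc1` gives 270 nM. Compound 3 `Cc1ccc(C(=O)N[C@@H]2[C@@H](O)[C@H](n3cnc4c(NC5CCCC5)ncnc43)O[C@@H]2CO)cc1F` differs from compound 2 in several places. In this assay compound 3 gives 112 nM. Compound 2 thus carries the highest of the three numbers: compound 1 sits nearest, as the step of a 1.1-fold higher number from compound 1 to compound 2 (0.05 log units; within the scatter) shows, while compound 3 lies beyond the scatter below it.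

Compound 4 `C[C@H]1O[C@@H](n2cnc3c(NC4CCCC4)ncnc32)[C@H](O)[C@H]1NC(=O)CCCc1cccs1` is not yet measured. It differs from compound 2 by 3-(thiophen-2-yl)propyl in place of 4-isopropylphenyl on a carbonyl carbon. For the measured compounds named here, the only measured step touching this part of the molecule is a 1.1-fold higher number from compound 1 to compound 2 (0.05 log units; within the scatter), a change within the aromatic substituent that left the number essentially unmoved. No measured pair exchanges the aromatic ring on the carbonyl for a chain, so the present change is not covered by any shown step. The expectation for compound 4 is therefore a step of a 1.5-fold higher number from compound 2 to compound 4 (0.17 log units; within the scatter) in this assay, with considerable uncertainty. Compound 4 is expected to give about 400 nM, between 100 nM and 1600 nM.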

Compound 4, inhibition constant: 55 nM
Compound 4: middle estimate off by 7.3-fold (0.86 log units), on the high side, and the stated range ends above it.
By their numbers in this assay, from the lowest: compound 4; then compound 3; then compounds 1 and 2 (each within the scatter of the next).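

For the compounds shown here, until this result, the only change on the carbonyl carbon was between 4-ethylphenyl and 4-isopropylphenyl, and it stayed within the scatter in this assay. Going by these compounds alone, exchanging either group for 3-(thiophen-2-yl)propyl gives the first steps beyond the scatter at this place (a 4.9-fold lower number from compound 2 to compound 4 (0.69 log units; beyond the scatter); a 4.4-fold lower number from compound 1 to compound 4 (0.64 log units; beyond the scatter)), so a group with its aromatic ring set out on a chain is accepted here and gives a lower number than both phenyl groups. No measurement shown accounts for these steps.

The five-membered aromatic ring and the propyl chain enter together, and the compounds shown do not tell which of the two carries the steps. Also open, from the compounds shown here alone, is how 3-phenylpropyl, or a shorter chain ending in the same thiophen-2-yl ring, would read in this assay.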